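Methoxy added to a chalcone-linked pyrazole: a small expected effect

This account rests on a few compounds, and the source may have more. Where it says the series, first, only, none or still open, it means among the compounds named here.

Compound 3 `COc1ccc(-c2cc(/C=C/C(=O)c3ccc(N)cc3)[nH]n2)cc1OC` is tested in a functional assay on HCT-15 cells (Homo sapiens) for cytotoxicity, read by sulforhodamine B assay, with a stated time of 48 h, tested at 0.1 uM (a higher number here means a weaker effect of the compound at the concentration tested, a lower number a stronger effect), and gives 95%. Compound 1 `COc1cc(-c2cc(/C=C/C(=O)c3ccc(N)cc3)[nH]n2)cc(OC)c1OC` carries one change against compound 3, (methoxy in place of hydrogen on an aromatic carbon), and in this assay compound 1 gives 94%, so that the step of a number 1 percentage points lower from compound 3 to compound 1 (within the scatter) is small. Compound 2 `COc1ccc(C(=O)/C=C/c2cc(-c3cc(OC)c(OC)c(OC)c3)n[nH]2)cc1OC` differs from compound 1 in another place, a number 4 percentage points higher from compound 1 to compound 2 (within the scatter), and in this assay compound 2 gives 98%. The difference between the cores of compound 2 and compound 3 is not broken down here; their two values lie close together.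

Compound 4 `COc1cc(C(=O)/C=C/c2cc(-c3cc(OC)c(OC)c(OC)c3)n[nH]2)cc(OC)c1OC` has not been measured in this assay. Against compound 2 it shows (methoxy in place of hydrogen on an aromatic carbon). Among the measured compounds shown here, this is the same change as the one from compound 3 to compound 1, because the step of a number 1 percentage points lower from compound 3 to compound 1 (within the scatter) was within the scatter, a step of similar size is expected from compound 2 to compound 4, namely a number 1 percentage points lower from compound 2 to compound 4 (within the scatter). Compound 4 is therefore estimated to give 97% in this assay, with an expected range from 88% to 102%.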

Compound 4, a percentage reported as activity, at one concentration (the size of the read-out at that concentration, not a potency): 94%
For compound 4 the middle estimate is 3 percentage points above the measured one, and the stated range covers the measured number.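

Methoxy in place of hydrogen on an aromatic carbon gives, in this assay, a step of a number 4 percentage points lower from compound 2 to compound 4 (within the scatter). Set beside the earlier case, the change reads alike on the two cores: the same change on two cores in this assay, a number 1 percentage points lower (within the scatter) from compound 3 to compound 1 and a number 4 percentage points lower (within the scatter) from compound 2 to compound 4, 3 percentage points apart, within the scatter of two such steps. This shows that in both pairs the change left the read-out within the usual scatter, but all the values lie close together at a single concentration, so it does not show that the change would behave alike on other cores or at a concentration where the numbers move further.

What the compounds shown leave open is whether a group other than methoxy at this place, such as a hydroxyl, a fluorine atom or a longer alkoxy chain, would shift the number in this assay. Also open, going by these compounds, is what a carboxylic acid or a simple alkyl chain would do on the carbonyl carbon in place of the 4-aminophenyl or 3,4-dimethoxyphenyl.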